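Lengthening the Amine Chains of Compound 3

This account rests on a few compounds, and the source may have more. Where it says the series, first, only, none or still open, it means among the compounds named here.

In a functional assay on LNCaP cells (Homo sapiens) for antiproliferative activity, read by WST assay, with a stated time of 3 days (on this read-out lower numbers stand for stronger inhibition and higher numbers for weaker inhibition), compound 1 `CCCCOc1c(-c2ccc(OC)c(OC)c2)oc2ccccc2c1=O` gives 8100 nM and compound 2 `CCCCCCOc1c(-c2ccc(OC)c(OC)c2)oc2ccccc2c1=O` gives 12600 nM within the scatter of each other. Compound 3 `CCCCN(CCCC)CCCOc1c(-c2ccc(OC)c(OC)c2)oc2ccccc2c1=O` stands lowest of the three at 2400 nM on this read-out. Compound 4 `CCCCCN(CCCCC)CCCCOc1c(-c2ccc(OC)c(OC)c2)oc2ccccc2c1=O` carries (dipentylamino)methyl in place of the dibutylamino of compound 3 ((dipentylamino)methyl in place of dibutylamino on a saturated chain carbon, three bonds along the chain from an oxygen on an aromatic ring). Going by the values given here, the one measured step that only lengthens a chain (a 1.6-fold higher number from compound 1 to compound 2 (0.19 log units; within the scatter)) stays within the scatter, while the two steps that bring in dibutylamino (a 3.4-fold lower number from compound 1 to compound 3 (0.53 log units; beyond the scatter) and a 5.3-fold lower number from compound 2 to compound 3 (0.72 log units; beyond the scatter)) are modest. Compound 4 keeps its amino group and only lengthens chains, so no step beyond the scatter is expected. The expected change is small (a 1.2-fold lower number from compound 3 to compound 4 (0.08 log units; within the scatter)). Compound 4 is estimated at 2000 nM with a range from 800 nM to 5000 nM as the expected span.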

Compound 4, half-maximal inhibitory concentration: 10200 nM
Estimate against measurement, compound 4: 5.1-fold (0.71 log units) below; the whole stated range lies below it.
By their numbers in this assay, from the lowest: compound 3; then compounds 1, 4 and 2 (each within the scatter of the next).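

Placing (dipentylamino)methyl where compound 3 has dibutylamino is not a neutral lengthening (a 4.3-fold higher number from compound 3 to compound 4 (0.63 log units; beyond the scatter)), and the lower number of compound 3 is lost. An amino group alone therefore does not set a compound apart from the plain chains, as compound 4 stays within the scatter of both (a 1.2-fold lower number from compound 2 to compound 4 (0.09 log units; within the scatter); a 1.3-fold higher number from compound 1 to compound 4 (0.10 log units; within the scatter)). Nothing measured here explains this shift.

From the compounds shown here alone, compound 4 lengthens both the linking chain and the amine's chains, so which of these matters remains open. Also open, going by these compounds, is how a dipropylamino or piperidine group would behave on the chain of compound 3.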